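Fluoro to trifluoromethoxy on the pendant ring

A few compounds are considered here, and "the series" means these few. Any claim that something is new, unique, unknown or untested is made for them only; others in the source may bear on it.

Compound 1 `Cc1ccc2nc(-c3ccccc3F)[nH]c(=O)c2c1` gives 36.3% in an assay on isolated protein for inhibition of DNA topoisomerase 1 (Homo sapiens), with a stated time of 30 min, tested at 20 uM (a higher number here means a stronger effect of the compound at the concentration tested, a lower number a weaker effect), and stands highest of the three measured compounds. Compound 2 `Cc1ccc2c(=O)[nH]c(-c3cccc(F)c3)nc2c1` gives 4.3% in this assay; the difference between the cores of compound 1 and compound 2 is not broken down here. Compound 3 `Cc1ccc2c(=O)[nH]c(-c3cccc(OC(F)(F)F)c3)nc2c1` gives 0%. The change trifluoromethoxy in place of fluoro on an aromatic carbon gave a number 4.3 percentage points lower from compound 2 to compound 3 (within the scatter). Compound 4 `Cc1ccc2nc(-c3ccccc3OC(F)(F)F)[nH]c(=O)c2c1` is not yet measured; it differs from compound 1 by trifluoromethoxy in place of fluoro on an aromatic carbon, the same kind of change, but here ortho to a large group rather than meta to a large group. Because compound 2 to compound 3 showed a number 4.3 percentage points lower from compound 2 to compound 3 (within the scatter), only a modest move is expected, with some allowance for the different place. The expected step is a number 12.3 percentage points lower from compound 1 to compound 4 (beyond the scatter). Compound 4 is estimated at 24%, between 6% and 42%.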

Compound 4, a percentage reported as inhibition, at one concentration (the size of the read-out at that concentration, not a potency): 0%
The estimate for compound 4 lay 24 percentage points above the measured number, outside the stated range (below it).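

Trifluoromethoxy in place of fluoro does not carry over as one fixed step between these cores in this assay: the same change on two cores in this assay, a number 4.3 percentage points lower (within the scatter) from compound 2 to compound 3 and a number 36.3 percentage points lower (beyond the scatter) from compound 1 to compound 4, 32 percentage points apart, beyond the scatter of two such steps

On the core of compound 1, the change is a number 36.3 percentage points lower from compound 1 to compound 4 (beyond the scatter) and takes the reading to the same printed number as compound 3. Compound 2 already gives only 4.3%, leaving little room for a fall, and the substituent's place also differs between the two pairs, so these data do not separate the effect of the core from that of the place.

Open, from the compounds shown here alone, is whether chloro, methoxy or an amine, ortho to a large group, would keep the reading of compound 1. Also open, going by these compounds, is how any of these would behave at other concentrations.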